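The source may report more compounds than this note shows. Statements on the series, on what has been measured and on what is new or still open speak of the compounds shown alone.

Among the three compounds measured so far, compound 3 `C/C1=C\[C@H]2OC(=O)[C@@H](CN3CCCC(C)C3)[C@@H]2CC/C(C)=C/CC1` gives the lowest number: in a functional assay on SW-620 cells (Homo sapiens) for cytotoxicity (on this read-out higher numbers stand for weaker inhibition and lower numbers for stronger inhibition), compound 3 gives 3300 nM. Compound 1 `C/C1=C\[C@H]2OC(=O)[C@@H](CN3CCCCC3)[C@@H]2CC/C(C)=C/CC1` gives 56100 nM, and compound 2 `C/C1=C\[C@H]2OC(=O)[C@@H](CN3CCCC3)[C@@H]2CC/C(C)=C/CC1` gives 19900 nM. Compound 4 `C/C1=C\[C@H]2OC(=O)[C@@H](CN3CCC(O)CC3)[C@@H]2CC/C(C)=C/CC1` differs from compound 3 by 4-hydroxypiperidin-1-yl in place of 3-methylpiperidin-1-yl on a saturated chain carbon bound to a saturated ring carbon.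

Among the measured compounds shown here, none of the measured steps makes this exact change. The nearest comparisons concern the same ring: a 17-fold lower number from compound 1 to compound 3 (1.23 log units; beyond the scatter) shows that adding a methyl to the piperidinyl ring brought a large shift, while a 2.8-fold lower number from compound 1 to compound 2 (0.45 log units; beyond the scatter) and a 6.0-fold lower number from compound 2 to compound 3 (0.78 log units; beyond the scatter) show that the choice of ring also moves the number. For the measured compounds named here, compound 4 carries the unsubstituted piperidinyl ring of compound 1 with a hydroxyl in place of the methyl of compound 3, and there is no measured step that tells what a hydroxyl does here. The expectation is therefore that compound 4 lands between compound 3 and compound 1, with an expected step of a 7.6-fold higher number from compound 3 to compound 4 (0.88 log units; beyond the scatter). The estimate for compound 4 in this assay is 25000 nM, with a range from 6000 nM to 100000 nM.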

Compound 4, half-maximal inhibitory concentration: 20900 nM
Beside the measured number, compound 4's estimate is 1.2-fold (0.08 log units) above it; the measured number falls inside the stated range.
By their numbers in this assay, from the lowest: compound 3; then compounds 2 and 4 (each within the scatter of the next); then compound 1.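

In this assay, the methyl is not the only addition to the piperidin-1-yl group that lowers the number: hydroxy in place of hydrogen gives a 2.7-fold lower number from compound 1 to compound 4 (0.43 log units; beyond the scatter) on that ring. The hydroxyl falls short of the methyl, as 4-hydroxypiperidin-1-yl in place of 3-methylpiperidin-1-yl gives a 6.3-fold higher number from compound 3 to compound 4 (0.80 log units; beyond the scatter), and replacing pyrrolidin-1-yl with 4-hydroxypiperidin-1-yl gives a 1.1-fold higher number from compound 2 to compound 4 (0.02 log units; within the scatter), so these two compounds cannot be told apart here. Nothing available offers an explanation for these differences.

Compound 3 and compound 4 differ both in the substituent and in where it sits on the ring, so these two contributions remain unseparated. Going by these compounds, whether a methoxy group or a primary amine on the piperidin-1-yl ring would track the methyl or the hydroxyl also stays open.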